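Swapping Phenoxy for Fluoro at the Far Aromatic Ring

A few compounds are considered here, and "the series" means these few. Any claim that something is new, unique, unknown or untested is made for them only; others in the source may bear on it.

Of the compounds shown here, three sharing one core have been tested in a functional assay on the whole organism (strain Wistar) for inhibition, with Rattus norvegicus as the target, read by paw edema, with stated times of 30 min and 5 h, at a dose of 0.05 mmol/kg by the oral route; on this read-out higher numbers stand for more inhibition at the one dose given (going by the name of the read-out) and lower numbers for less inhibition. Compound 1 `Cc1cc(C2=NN(c3ccc(S(C)(=O)=O)cc3)C(=O)CC2)ccc1O` gives 60.5%, compound 2 `CS(=O)(=O)c1ccc(N2N=C(c3ccc(Cl)cc3)CCC2=O)cc1` gives 36.8%, and compound 3 `CS(=O)(=O)c1ccc(N2N=C(c3ccc(Oc4ccccc4)cc3)CCC2=O)cc1` gives 65.7%, the highest of the three numbers, though its gap to compound 1 lies within the scatter. Compound 4 `CS(=O)(=O)c1ccc(N2N=C(c3ccc(F)cc3)CCC2=O)cc1` has not yet been measured. It differs from compound 3 in one place: fluoro in place of phenoxy on an aromatic carbon. The measured step that bears most directly on this change is a number 28.9 percentage points higher from compound 2 to compound 3 (beyond the scatter), where chloro gave way to phenoxy; returning to a halogen suggests a drop of comparable size. The step of a number 23.7 percentage points lower from compound 1 to compound 2 (beyond the scatter) concerns a different part of the molecule. A step of a number 25.7 percentage points lower from compound 3 to compound 4 (beyond the scatter) is therefore expected. Compound 4 is estimated at 40%, within a range from 25% to 58%.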

Compound 4, a percentage reported as inhibition, in the whole organism at one dose (the size of the read-out at that dose, not a potency): 73.6%
The estimate for compound 4 lay 33.6 percentage points below the measured number; measured number above the stated range.
By their numbers in this assay, from the lowest: compound 2; then compounds 1, 3 and 4 (each within the scatter of the next, the first and the last beyond it).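

In this assay the phenoxy ring is not required at this aromatic carbon, since a number 7.9 percentage points higher from compound 3 to compound 4 (within the scatter) is the step when fluoro replaces it. The two halogens do not behave alike here: a number 36.8 percentage points higher from compound 2 to compound 4 (beyond the scatter) is the step from chloro to fluoro, so compound 2 cannot speak for halogens in general. The 4-fluorophenyl group also compares well with the 4-hydroxy-3-methylphenyl group, with a number 13.1 percentage points higher from compound 1 to compound 4 (beyond the scatter) as the step.

Nothing available explains the gap between fluoro and chloro. On these data alone, whether an amine or a methoxy group at this carbon would match fluoro or chloro remains open.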